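Sulfonyl aryl swap carried onto the chloro core

The source may report more compounds than this note shows. Statements on the series, on what has been measured and on what is new or still open speak of the compounds shown alone.

Compound 1 `COc1ccc(S(=O)(=O)NCCCNc2nccc(-c3[nH]c(-c4ccccc4)nc3-c3ccc(F)c(OC)c3)n2)cc1` gives 6130 nM in a functional assay on LOX IMVI cells (Homo sapiens) for cytotoxicity, read by MTT assay, with a stated time of 24 h; a higher number here means a weaker inhibitor, a lower number a stronger inhibitor. Compound 2 `COc1cc(-c2nc(-c3ccccc3)[nH]c2-c2ccnc(NCCCNS(=O)(=O)c3cccc4ccccc34)n2)ccc1F` gives 14900 nM in this assay; the change is naphthalen-1-yl in place of 4-methoxyphenyl on a sulfonyl sulfur, and the step is a 2.4-fold higher number from compound 1 to compound 2 (0.39 log units; beyond the scatter). Compound 3 `COc1ccc(S(=O)(=O)NCCCNc2nccc(-c3[nH]c(-c4ccccc4)nc3-c3ccc(Cl)c(OC)c3)n2)cc1` gives 1800 nM in this assay, the lowest of the three numbers, with both steps to the others beyond the scatter; it differs from compound 1 by chloro in place of fluoro on an aromatic carbon, the step being a 3.4-fold lower number from compound 1 to compound 3 (0.53 log units; beyond the scatter). Compound 4 `COc1cc(-c2nc(-c3ccccc3)[nH]c2-c2ccnc(NCCCNS(=O)(=O)c3cccc4ccccc34)n2)ccc1Cl` is not yet measured in this assay. It differs from compound 3 by naphthalen-1-yl in place of 4-methoxyphenyl on a sulfonyl sulfur, the same change as made from compound 1 to compound 2, now placed on the core of compound 3. For compound 4 the expected step is a 2.4-fold higher number from compound 3 to compound 4 (0.38 log units; beyond the scatter), resting on the same change having given a 2.4-fold higher number from compound 1 to compound 2 (0.39 log units; beyond the scatter) and on compound 3 standing at 1800 nM. Compound 4 is thus estimated at 4300 nM in this assay, between 2000 nM and 9500 nM.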

Compound 4, half-maximal inhibitory concentration: 13500 nM
Beside the measured number, compound 4's estimate is 3.1-fold (0.50 log units) below it, outside the stated range (above it).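

Naphthalen-1-yl in place of 4-methoxyphenyl gives a 7.5-fold higher number from compound 3 to compound 4 (0.88 log units; beyond the scatter) in this assay, the same direction as on the core of compound 1 but not the same size: the same change on two cores in this assay, a 2.4-fold higher number (0.39 log units; beyond the scatter) from compound 1 to compound 2 and a 7.5-fold higher number (0.88 log units; beyond the scatter) from compound 3 to compound 4, 3.1-fold (0.49 log units) apart, beyond the scatter of two such steps

Chloro in place of fluoro gives a 1.1-fold lower number from compound 2 to compound 4 (0.04 log units; within the scatter), so the lower number seen with 4-methoxyphenyl on the sulfonyl sulfur does not carry over to the naphthalen-1-yl pair: the same change on two cores in this assay, a 3.4-fold lower number (0.53 log units; beyond the scatter) from compound 1 to compound 3 and a 1.1-fold lower number (0.04 log units; within the scatter) from compound 2 to compound 4, 3.1-fold (0.49 log units) apart, beyond the scatter of two such steps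

The two changes therefore do not add independently across these four compounds, but the data do not show what lies behind this or whether it holds on any other core.

Open, on these data alone, is how a plain phenyl or a thiophene on the sulfonyl sulfur would behave on either core. Also open, as far as these compounds go, is whether a bromo group in place of chloro, or a longer chain to the sulfonamide nitrogen, would follow the same pattern.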